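Swapping a chlorophenyl for a methylpyridinyl on the amide

The source may report more compounds than this note shows. Statements on the series, on what has been measured and on what is new or still open speak of the compounds shown alone.

Three measured compounds share one core and differ only in the group on the amide nitrogen. Compound 1 `O=C(Nc1ccc(Cl)cc1)c1c(O)c2cccnc2n(-c2ccccc2)c1=O` carries a 4-chlorophenyl there; in a functional assay on the whole organism for inhibition, with Rattus norvegicus as the target, read by paw edema, at a dose of 100 mg/kg by the oral route (on this read-out higher numbers stand for more inhibition at the one dose given (going by the name of the read-out) and lower numbers for less inhibition), compound 1 gives 11.6%, the lowest of the three numbers. Compound 2 `O=C(Nc1ccncc1)c1c(O)c2cccnc2n(-c2ccccc2)c1=O` gives 34.9% and compound 3 `O=C(NCc1cccnc1)c1c(O)c2cccnc2n(-c2ccccc2)c1=O` gives 25.5%. Both a number 23.3 percentage points higher from compound 1 to compound 2 (beyond the scatter) and a number 13.9 percentage points higher from compound 1 to compound 3 (beyond the scatter) lie beyond the scatter, whereas a number 9.4 percentage points lower from compound 2 to compound 3 (within the scatter) does not. Compound 4 `Cc1cnccc1NC(=O)c1c(O)c2cccnc2n(-c2ccccc2)c1=O` differs from compound 1 as follows: 3-methylpyridin-4-yl in place of 4-chlorophenyl on an amide-type nitrogen. The entering 3-methylpyridin-4-yl resembles the pyridin-4-yl of compound 2, so the guiding step is a number 23.3 percentage points higher from compound 1 to compound 2 (beyond the scatter), and a rise of roughly that size is expected, a number 19.4 percentage points higher from compound 1 to compound 4 (beyond the scatter). Compound 4 is therefore estimated at 31%, with a range from 15% to 48%.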

Compound 4, a percentage reported as inhibition, in the whole organism at one dose (the size of the read-out at that dose, not a potency): 26.9%
For compound 4 the middle estimate is 4.1 percentage points above the measured one; the range from low to high includes it.
By their numbers in this assay, from the lowest: compound 1; then compounds 3, 4 and 2 (each within the scatter of the next).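

Adding a methyl to the pyridin-4-yl keeps the gain over the 4-chlorophenyl on the amide nitrogen, with a number 15.3 percentage points higher from compound 1 to compound 4 (beyond the scatter) in this assay. The methyl itself makes no readable difference, with a number 8 percentage points lower from compound 2 to compound 4 (within the scatter) as its step. The 3-methylpyridin-4-yl also cannot be told apart from the (pyridin-3-yl)methyl, with a number 1.4 percentage points higher from compound 3 to compound 4 (within the scatter) as the step. Nothing measured here accounts for these numbers. Open, as far as these compounds go, is what a methoxy group or a longer chain in place of that methyl would give.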